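Adding a second hydroxy to compound 3

The source may report more compounds than this note shows. Statements on the series, on what has been measured and on what is new or still open speak of the compounds shown alone.

Compound 1 `COc1cccc(/C=C2\CCC/C(=C\c3cccc(Cl)c3)C2=O)c1OC` gives 21400 nM
Compound 2 `COc1cc(/C=C2\CCC/C(=C\c3cccc(OC)c3OC)C2=O)ccc1O` gives 14300 nM
Compound 3 `COc1ccc(/C=C2\CCC/C(=C\c3cccc(O)c3)C2=O)cc1OC` gives 6800 nM

These three compounds were tested in an ADME assay on NHDF cells (Homo sapiens) for cytotoxicity, read by MTT assay, with a stated time of 72 h (a lower number here means a stronger inhibitor, a higher number a weaker inhibitor), and compound 3 holds the lowest number of the set, which makes it the strongest inhibitor of the three. Compound 4 `COc1ccc(/C=C2\CCC/C(=C\c3ccc(O)c(O)c3)C2=O)cc1OC` has not yet been measured. It differs from compound 3 in a single place: hydroxy in place of hydrogen on an aromatic carbon sums up the swap. A hydroxy takes the place of hydrogen on an aromatic carbon, ortho to a hydroxy group and para to a large group, so that 3-hydroxyphenyl becomes 3,4-dihydroxyphenyl.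

Among the compounds with values here, only one measured step offers any guidance. The change a 1.5-fold lower number from compound 1 to compound 2 (0.18 log units; within the scatter) came with 4-hydroxy-3-methoxyphenyl in place of 3-chlorophenyl, and it lies within the scatter. That step also brought in a hydroxy group, so it is the closest guide, although it is not the same change. Within the data shown here, no measured step adds a hydroxy to a ring that already carries one, so the direction cannot be told with confidence. What is expected is a 1.1-fold lower number from compound 3 to compound 4 (0.05 log units; within the scatter) and nothing beyond the scatter. Compound 4 is estimated at 6000 nM within an expected range from 2200 nM to 16000 nM.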

Compound 4, half-maximal inhibitory concentration: 25200 nM
The estimate for compound 4 lay 4.2-fold (0.62 log units) below the measured number, and the stated range ends below it.
By their numbers in this assay, from the lowest: compound 3; then compounds 2, 1 and 4 (each within the scatter of the next).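

In this assay, hydroxy in place of hydrogen on this aromatic carbon, ortho to a hydroxy group and para to a large group, brings a 3.7-fold higher number from compound 3 to compound 4 (0.57 log units; beyond the scatter), so this position does respond to the change and the added hydroxy goes with weaker inhibition. Within the data shown here, this is the first single-place step in the set to lie beyond the scatter, since the earlier step that brought in a hydroxy group stayed within it, and so gaining a hydroxy does not leave the number unchanged in every setting. The rest of the structure is the same in both compounds, which ties the step to this one added group, although a single pair sets no general rule. Nothing measured here accounts for the rise.

Going by these compounds, it remains open whether the higher number belongs to hydroxy specifically or would also come with another group on the same carbon, such as an amine or a carboxylic acid. On these data alone, it is also open whether the same swap would give a step of similar size with a different group on the other side of the shared core.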